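Dimethylamino for propoxy on the core of compound 1

The source may hold more compounds than are shown below. What is called first, only, known or untested is meant among the compounds shown, and "the series" means these compounds.

The study concerns the shared core of compound 1 `CCCOc1ccc(-c2nc3cc(C(F)(F)F)ccc3[nH]2)cc1`, which in a functional assay on aorta (Rattus norvegicus, strain Wistar) for inhibition, with a stated time of 60 min (on this read-out lower numbers stand for an effect already at smaller amounts and higher numbers for an effect only at larger amounts of compound), gives 524000 nM. That is the highest of the three numbers recorded: compound 2 `COc1ccccc1-c1nc2cc(C(F)(F)F)ccc2[nH]1` gives 210000 nM, and compound 3 `COc1ccc(-c2nc3cc([N+](=O)[O-])ccc3[nH]2)c(OC)c1OC` gives 3230 nM, both far lower, well beyond the scatter. Among the measured compounds shown here, no step between two measured compounds differing in one place exists here, so the effect of any single change is open. Compound 4 `CN(C)c1ccc(-c2nc3cc(C(F)(F)F)ccc3[nH]2)cc1` is as yet unmeasured; it differs from compound 1 by dimethylamino in place of propoxy on an aromatic carbon. For the measured compounds named here, with no comparable step to lean on, a modest change is expected, if any beyond the scatter, more likely toward a lower number. Compound 4 is therefore estimated at 300000 nM, within 80000 nM to 1200000 nM, a step of a 1.7-fold lower number from compound 1 to compound 4 (0.24 log units; within the scatter).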

Compound 4, half-maximal effective concentration: 550000 nM
Estimate against measurement, compound 4: 1.8-fold (0.26 log units) below; the range from low to high includes it.
By their numbers in this assay, from the lowest: compound 3; then compound 2; then compounds 1 and 4 (each within the scatter of the next).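

In this assay, among the compounds shown here, dimethylamino in place of propoxy on an aromatic carbon, para to a large group, gives a 1.0-fold higher number from compound 1 to compound 4 (0.02 log units; within the scatter) and is the only comparison here that differs in one place. On this read-out, the two groups cannot be told apart at this position. No measurement shown offers an explanation for this.

From the compounds shown here alone, whether an amine or a carboxylic acid on this aromatic carbon would give a different number remains open. Also open, going by these compounds, is which of the differences between compound 1 and compound 3 goes with the 3230 nM of compound 3.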